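The source may hold more compounds than are shown below. What is called first, only, known or untested is meant among the compounds shown, and "the series" means these compounds.

Compound 1 `COc1ccc(-c2nc(CNc3ccc(C(=O)NO)cc3)n(-c3ccccc3)n2)cc1`: 77.6%
Compound 2 `Cc1ccc(-n2nc(-c3ccccc3)nc2CNc2ccc(C(=O)NO)cc2)cc1C`: 53%

Of the two measured compounds, compound 1 stands highest in an assay on Sf9 cells for inhibition of protein deacetylase HDAC6 (Homo sapiens), read by fluorescence, with a stated time of 40 min, tested at 100 nM; a higher number here means more inhibition at the concentration tested (going by the name of the read-out), a lower number less inhibition; compound 2 lies lower by a gap beyond the usual scatter. Compound 3 `O=C(NO)c1ccc(NCc2nc(-c3ccccc3Cl)nn2-c2ccccc2)cc1` has not yet been measured. It differs from compound 1 in one place: 2-chlorophenyl in place of 4-methoxyphenyl on an aromatic carbon. Among the compounds with values here, no measured pair shows this change on its own, so nothing about its effect is known from the data. In this assay a modest downward step, or none beyond the scatter, is expected. Compound 3 is estimated at 66%, with a likely range from 42% to 84%. In this assay the expected step is a number 11.6 percentage points lower from compound 1 to compound 3 (beyond the scatter).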

Compound 3, a percentage reported as inhibition, at one concentration (the size of the read-out at that concentration, not a potency): 75%
The estimate for compound 3 lay 9 percentage points below the measured number, and the stated range covers the measured number.
By their numbers in this assay, from the lowest: compound 2; then compounds 3 and 1 (each within the scatter of the next).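

In this assay, putting 2-chlorophenyl in place of 4-methoxyphenyl on the aromatic carbon between two ring nitrogen atoms gives a number 2.6 percentage points lower from compound 1 to compound 3 (within the scatter), so the read-out does not separate these two groups at this position. The change removes the one hydrogen-bond acceptor counted on the group, and the step still stays within the scatter. No measurement at hand explains why the two compounds read alike. The compounds shown leave open how a carboxylic acid or an amine on this phenyl ring would read, and whether chlorine placed elsewhere on the ring would read the same.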